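Trimming a Methyl and Monkey Oral Bioavailability

A few compounds are considered here, and "the series" means these few. Any claim that something is new, unique, unknown or untested is made for them only; others in the source may bear on it.

Measured compounds:
compound 1 `CC(C)CCn1nc(CC(C)(C)C)c(O)c(C2=NS(=O)(=O)c3cc(NS(C)(=O)=O)ccc3N2)c1=O`: 6%
compound 2 `CC(C)(C)CCn1nc(CC(C)(C)C)c(O)c(C2=NS(=O)(=O)c3cc(NS(C)(=O)=O)ccc3N2)c1=O`: 4%
compound 3 `CN(c1ccc2c(c1)S(=O)(=O)N=C(c1c(O)c(-c3cccs3)nn(CCC(C)(C)C)c1=O)N2)S(C)(=O)=O`: 3%

In an in vivo ADME assay on the whole organism for pharmacokinetics, with Cynomolgus monkey (Macaca fascicularis) as the target, at a dose of 1 mg/kg by the oral route (on this read-out lower numbers stand for lower oral bioavailability and higher numbers for higher oral bioavailability), compound 1 gives 6%, compound 2 gives 4% and compound 3 gives 3%. Compound 2 and compound 1 differ by hydrogen in place of methyl on a saturated chain carbon bound to three saturated chain carbons, and this change gave a number 2 percentage points higher from compound 2 to compound 1 (within the scatter). Compound 4 `CC(C)CCn1nc(-c2cccs2)c(O)c(C2=NS(=O)(=O)c3cc(N(C)S(C)(=O)=O)ccc3N2)c1=O` has not been measured; it differs from compound 3 by hydrogen in place of methyl on a saturated chain carbon bound to three saturated chain carbons, the same change at the same place. How the core of compound 3 differs from the core of compound 2 is not broken down here. The earlier step of a number 2 percentage points higher from compound 2 to compound 1 (within the scatter) stayed within the usual scatter, so for compound 4 a similarly small step is expected, a number 2 percentage points higher from compound 3 to compound 4 (within the scatter). Compound 4 is estimated at 5%, with a likely range from 1% to 12%.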

Compound 4, oral bioavailability: 12%
Compound 4: the middle estimate sits 7 percentage points below what was measured, and the stated range covers the measured number.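

In this assay, swapping 3,3-dimethylbutyl for isopentyl gives a number 9 percentage points higher from compound 3 to compound 4 (within the scatter). Set beside the earlier step, the result gives no reason to treat the two cores differently: the same change on two cores in this assay, a number 2 percentage points higher (within the scatter) from compound 2 to compound 1 and a number 9 percentage points higher (within the scatter) from compound 3 to compound 4, 7 percentage points apart, within the scatter of two such steps This shows that the change can be carried from one core to the other without a detectable difference between the steps, but it does not show that the steps are equal, or that the change has a real effect on either core, as each step stays within the usual scatter.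

From the compounds shown here alone, only two chains are compared here, so the outcome in this assay for a longer chain, or for a chain ending in an amine or a carboxylic acid, remains open. Going by these compounds, whether the step would hold on a third core also remains open.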